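Bromobenzyl regioisomers in a gastric cell toxicity series

The source may hold more compounds than are shown below. What is called first, only, known or untested is meant among the compounds shown, and "the series" means these compounds.

Measured so far:
compound 1 `Cc1cc(N2CC[C@@H](C)[C@@H](N(C)c3ncnc4[nH]ccc34)C2)n2nc(SCc3ccccc3Br)nc2n1` — > 100000 nM
compound 2 `CCCCCc1c(C)nc2nc(SCc3ccc(Cl)cc3)nn2c1N1CC[C@@H](C)[C@@H](N(C)c2ncnc3[nH]ccc23)C1` — > 100000 nM

In a toxicity assay on GES1 cells (Homo sapiens) for inhibition, read by MTT assay, with a stated time of 72 h (a higher number here means a weaker inhibitor, a lower number a stronger inhibitor), compound 1 shows only a limit, > 100000 nM. Compound 2 likewise gives only a limit in this assay, > 100000 nM. Both values sit at the limit of > 100000 nM in this assay, at which 2 of the 2 values shown sit, so compound 1 cannot be placed against compound 2 on the numbers shown.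

Compound 3 `Cc1cc(N2CC[C@@H](C)[C@@H](N(C)c3ncnc4[nH]ccc34)C2)n2nc(SCc3ccc(Br)cc3)nc2n1` differs from compound 1 in one place: 4-bromophenyl in place of 2-bromophenyl on a saturated chain carbon bound to a sulfur. For the measured compounds named here, no step between measured compounds is available to size this change. Compound 3 is expected to stay at the limit, the step that the limit leaves unreadable from compound 1 to compound 3 being expected within the scatter. Compound 3 is estimated at 150000 nM, from 50000 nM to 500000 nM.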

Compound 3, half-maximal inhibitory concentration: 55600 nM
Beside the measured number, compound 3's estimate is 2.7-fold (0.43 log units) above it; measured number inside the range.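

In this assay, for the compounds shown here, 4-bromophenyl in place of 2-bromophenyl on a saturated chain carbon bound to a sulfur gives an at least 1.7-fold lower number from compound 1 to compound 3 (0.25 log units; that floor lies within the scatter), and compound 3 supplies the first number that is not a limit. The true size of this step remains unread, as compound 1 gives only a limit. Most values still sit at that limit: the limit of > 100000 nM in this assay, at which 2 of the 3 values shown sit.

Still open, as far as these compounds go, is whether an amine or a carboxylic acid in place of the bromine would give a number clearly beyond the scatter.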